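Working notes: expected activity of compound 4

This account rests on a few compounds, and the source may have more. Where it says the series, first, only, none or still open, it means among the compounds named here.

Measured so far:
compound 1 `O=C(Nc1cccc(-n2cc(-c3ccncc3)c(-c3cc(O)cc(Cl)c3)n2)c1)Nc1ccc(Cl)c(C(F)(F)F)c1`: 6.95%
compound 2 `COc1cc(Cl)cc(-c2nn(-c3cccc(NC(=O)Nc4ccc(Cl)c(C(F)(F)F)c4)c3)cc2-c2ccncc2)c1`: 3.39%
compound 3 `COc1cc(Cl)cc(-c2nn(-c3cccc(NC(=O)Nc4cc(C(F)(F)F)cc(C(F)(F)F)c4)c3)cc2-c2ccncc2)c1`: -4.6%

In a functional assay on HCT-116 cells (Homo sapiens) for inhibition, read by sulforhodamine B assay, with a stated time of 48 h, tested at 10 uM (a lower number here means a stronger effect, a higher number a weaker effect of the compound at the concentration tested), compound 2 stands second highest of the three numbers, nearest to compound 1 and furthest from compound 3, both gaps within the scatter. For the measured compounds named here, the only measured step, a number 3.6 percentage points lower from compound 1 to compound 2 (within the scatter), lies within the scatter as well. Compound 4 `COc1cc(Cl)cc(-c2nn(-c3cccc(NC(=O)c4cccc(C(F)(F)F)c4)c3)cc2-c2ccncc2)c1` differs from compound 2 by 3-(trifluoromethyl)phenyl in place of (4-chloro-3-(trifluoromethyl)phenyl)amino on a carbonyl carbon. Going by the values given here, no measured step touches this part of the molecule, so nothing points to a change beyond the scatter in this assay. Compound 4 is therefore expected near compound 2, at 3% with a range of -8% to 14%. The expected step is a number 0.4 percentage points lower from compound 2 to compound 4 (within the scatter).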

Compound 4, a percentage reported as activity, at one concentration (the size of the read-out at that concentration, not a potency): 34.1%
The estimate for compound 4 lay 31.1 percentage points below the measured number; measured number outside the range, above it.
By their numbers in this assay, from the lowest: compounds 3, 2 and 1 (each within the scatter of the next, the first and the last beyond it); then compound 4.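

In this assay, the group on the carbonyl carbon is the only place among the compounds shown where a change moves the number beyond the scatter, with a number 30.7 percentage points higher from compound 2 to compound 4 (beyond the scatter). The entering 3-(trifluoromethyl)phenyl lacks both the nitrogen and the chlorine of the leaving group, and this single step cannot separate the two. No measurement shown accounts for the weaker effect.

As far as these compounds go, whether the nitrogen or the chlorine carries the difference remains open. A 3-(trifluoromethyl)phenylamino group or a 4-chloro-3-(trifluoromethyl)phenyl group on the carbonyl carbon would divide the step.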